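This account rests on a few compounds, and the source may have more. Where it says the series, first, only, none or still open, it means among the compounds named here.

Compound 1 `Cc1ccc(S(=O)(=O)/N=C(/CCNC2=CC(=O)c3ccccc3C2=O)Nc2ccc(Cl)cc2)cc1` was tested in an ADME assay on HEK293 cells (Homo sapiens) for cytotoxicity, read by MTT assay, with a stated time of 48 h (a higher number here means a weaker inhibitor, a lower number a stronger inhibitor), and gave 65400 nM there. Among the three compounds measured, compound 1 has the smallest number, though the gaps to the other two fall within the scatter. Compound 2 `Cc1ccc(S(=O)(=O)/N=C(/CCNC2=CC(=O)c3ccccc3C2=O)Nc2ccccc2[N+](=O)[O-])cc1` gave 69600 nM in this assay, and compound 3 `COc1ccc(N/C(CCNC2=CC(=O)c3ccccc3C2=O)=N\S(=O)(=O)c2ccc(C)cc2)c(OC)c1` gave 83000 nM. The steps are a 1.1-fold higher number from compound 1 to compound 2 (0.03 log units; within the scatter), a 1.3-fold higher number from compound 1 to compound 3 (0.10 log units; within the scatter) and a 1.2-fold higher number from compound 2 to compound 3 (0.08 log units; within the scatter), each a change of the aryl group on the amine nitrogen, and none moves the number beyond the scatter.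

Compound 4 `Cc1ccc(S(=O)(=O)/N=C(/CCNC2=CC(=O)c3ccccc3C2=O)Nc2cc(F)c(F)c(F)c2)cc1` is the next variation on the same site. Compared with compound 1 it differs in this way: 3,4,5-trifluorophenyl in place of 4-chlorophenyl on an amine nitrogen. All three measured steps bear on this change, since each also swaps the aryl group on the amine nitrogen, and all three were small. Compound 4 is therefore expected to show no step beyond the scatter in this assay, and the expected step is a 1.1-fold higher number from compound 1 to compound 4 (0.03 log units; within the scatter). The estimate for compound 4 is 70000 nM, with a range from 40000 nM to 125000 nM.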

Compound 4, half-maximal inhibitory concentration: 82600 nM
Estimate against measurement, compound 4: 1.2-fold (0.07 log units) below; measured number inside the range.
By their numbers in this assay, from the lowest: compounds 1, 2, 4 and 3 (each within the scatter of the next).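

In this assay, the 3,4,5-trifluorophenyl group on the amine nitrogen stays level with each of the three earlier aryl groups (a 1.3-fold higher number from compound 1 to compound 4 (0.10 log units; within the scatter); a 1.2-fold higher number from compound 2 to compound 4 (0.07 log units; within the scatter); a 1.0-fold lower number from compound 3 to compound 4 (0.00 log units; within the scatter)). The earlier compounds shown here carried chloro, nitro or methoxy groups on the ring, and a ring bearing fluorine alone now joins them without any step beyond the scatter. The four aryl groups shown therefore cannot be told apart at this position, and nothing measured here accounts for that.

Still open, from the compounds shown here alone, is whether something other than a substituted phenyl on this nitrogen, such as a pyridine ring, a benzyl group or an alkyl chain, would give a step beyond the scatter. A phenyl bearing a carboxylic acid or an amine is equally untested among these compounds, as is any change elsewhere on the shared core.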